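Series notes: aryl change on the shared core

The source may hold more compounds than are shown below. What is called first, only, known or untested is meant among the compounds shown, and "the series" means these compounds.

Compound 1 `Cc1ccc(-c2noc(COc3ccc(CCC(=O)O)cc3)n2)cc1` gives 300 nM in a functional assay on CHO cells for agonist activity at Free fatty acid receptor 1 (Homo sapiens), read by FLIPR and calcium flux, in the presence of a further agent that is not named here (a lower number here means that less compound is needed, a higher number that more compound is needed for the effect), the lowest number among the three measured compounds. Compound 3 `CC(Oc1ccc(CCC(=O)O)cc1)c1nc(-c2ccccc2)no1` gives 2390 nM in this assay, and compound 2 `O=C(O)CCc1ccc(OCc2nc(-c3ccccc3)no2)c(Cl)c1` gives 13100 nM; both gaps to compound 1 lie beyond the scatter. Compound 4 `O=C(O)CCc1ccc(OCc2nc(-c3ccccc3Cl)no2)cc1` has not been measured in this assay. It differs from compound 1 in one place: 2-chlorophenyl in place of 4-methylphenyl on an aromatic carbon. Among the measured compounds shown here, no measured pair isolates this change, so the size of the step rests on expectation alone. The two other measured compounds, each with a plain phenyl at this position, sit well above compound 1, so a loss is expected rather than a gain. Compound 4 is estimated at 1500 nM (range 400 nM to 6000 nM), an expected step of a 5.0-fold higher number from compound 1 to compound 4 (0.70 log units; beyond the scatter) beyond the scatter.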

Compound 4, half-maximal effective concentration: 1200 nM
Beside the measured number, compound 4's estimate is 1.3-fold (0.10 log units) above it; the measured number falls inside the stated range.
By their numbers in this assay, from the lowest: compound 1; then compounds 4 and 3 (each within the scatter of the next); then compound 2.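

The first step read at this position in this assay is a 4.0-fold higher number from compound 1 to compound 4 (0.60 log units; beyond the scatter) and is modest. Replacing 4-methylphenyl with 2-chlorophenyl on the aromatic carbon between two ring nitrogen atoms therefore costs activity but does not abolish it, and the group's heavy-atom count stays the same. Nothing at hand accounts for the step.

Methyl and chlorine change here together with their place on the phenyl ring, so the compounds shown cannot separate the two effects. Going by these compounds, how plain phenyl on the unchanged core, or a methoxy- or amine-bearing phenyl, would read at this position remains open.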